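Extending a sulfonamide-linked piperazine in an adenosine A3 binding series

A few compounds are considered here, and "the series" means these few. Any claim that something is new, unique, unknown or untested is made for them only; others in the source may bear on it.

Measured compounds:
Compound 1 `CCCn1c(=O)[nH]c2nc(-c3ccc(S(=O)(=O)N4CCN(Cc5cccc(C)c5)CC4)cc3)[nH]c2c1=O`: 17%
Compound 2 `CCCn1c(=O)[nH]c2nc(-c3ccc(S(=O)(=O)N4CCN(C)CC4)cc3)[nH]c2c1=O`: 7%

Compound 1 and compound 2 were both tested in an assay on CHO cells for displacement of a labelled ligand from adenosine receptor A3 (Homo sapiens), read by scintillation counting, with a stated time of 45 min, tested at 1 uM, in the presence of a further agent that is not named here; a lower number here means less inhibition, a higher number more inhibition at the concentration tested (going by the name of the read-out). Among the measured compounds shown here, compound 2 gives the lower of the two numbers, but its nearest neighbour is compound 1, and the one step between them, a number 10 percentage points lower from compound 1 to compound 2 (within the scatter), is within the scatter, so the two cannot be ordered. That step replaced hydrogen with 3-methylphenyl on a saturated chain carbon bound to an amine nitrogen in a ring.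

Compound 3 `CCCn1c(=O)[nH]c2nc(-c3ccc(S(=O)(=O)N4CCN(Cc5cccc(Br)c5)CC4)cc3)[nH]c2c1=O` is not yet measured. It differs from compound 2 by 3-bromophenyl in place of hydrogen on a saturated chain carbon bound to an amine nitrogen in a ring. For the measured compounds named here, the only step that bears on this change is the one from compound 1 to compound 2, and it was small. Compound 3 is therefore expected to land near compound 1, with a step from compound 2 of a number 9 percentage points higher from compound 2 to compound 3 (within the scatter), not beyond the scatter. The estimate for compound 3 is 16%, with a range from 3% to 32%.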

Compound 3, a percentage reported as inhibition, at one concentration (the size of the read-out at that concentration, not a potency): 23%
Compound 3: middle estimate off by 7 percentage points, on the low side; low and high end bracket the measured number.
By their numbers in this assay, from the lowest: compounds 2, 1 and 3 (each within the scatter of the next, the first and the last beyond it).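

In this assay, the change at this position now gives a step that can be read, a number 16 percentage points higher from compound 2 to compound 3 (beyond the scatter), which the 3-methylphenyl of compound 1 did not give against compound 2. The change on the aromatic carbon gives a number 6 percentage points higher from compound 1 to compound 3 (within the scatter), so bromo and methyl cannot be ordered here, and the gain over compound 2 can be claimed only for the 3-bromobenzyl group of compound 3, not for the two aryl groups alike. No measurement at hand explains this step.

The compounds shown leave open whether an unsubstituted benzyl group, or a phenyl ring bearing a methoxy group or a carboxylic acid, would stand with compound 3 or with compound 2. They also leave open whether a longer chain carrying the 3-bromophenyl ring would move the number further.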